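This account rests on a few compounds, and the source may have more. Where it says the series, first, only, none or still open, it means among the compounds named here.

Compound 1 `CC(C)Cc1ccc(C(C)C(=O)NCc2ccc(F)cc2)cc1` and compound 2 `CC(C)Cc1ccc(C(C)C(=O)NCc2ccc(C(F)(F)F)cc2)cc1` share one core and differ only at the aromatic ring. In an assay on brain for inhibition of Fatty-acid amide hydrolase 1 (Rattus norvegicus), read by scintillation counting, with a stated time of 10 min (a higher number here means a weaker inhibitor, a lower number a stronger inhibitor), compound 1 gives 27000 nM, and compound 2 gives 51000 nM; the step of a 1.9-fold higher number from compound 1 to compound 2 (0.28 log units; within the scatter) is within the scatter, so compound 1 stands apart from compound 2 by no more than repeated measurement would show. Compound 3 `CC(C)Cc1ccc(C(C)C(=O)NCc2ccc(Cl)cc2Cl)cc1` differs from compound 1 by 2,4-dichlorophenyl in place of 4-fluorophenyl on a saturated chain carbon bound to an amide-type nitrogen. For the measured compounds named here, the only step seen on that ring is a 1.9-fold higher number from compound 1 to compound 2 (0.28 log units; within the scatter), which was within the scatter, so no step beyond the scatter is expected in this assay. Compound 3 is therefore estimated at 35000 nM, between 12000 nM and 100000 nM, a step of a 1.3-fold higher number from compound 1 to compound 3 (0.11 log units; within the scatter) expected from the earlier number.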

Compound 3, half-maximal inhibitory concentration: 21000 nM
Compound 3: middle estimate off by 1.7-fold (0.22 log units), on the high side, within the range that was stated.
By their numbers in this assay, from the lowest: compounds 3, 1 and 2 (each within the scatter of the next, the first and the last beyond it).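

In this assay, 2,4-dichlorophenyl in place of 4-fluorophenyl on a saturated chain carbon bound to an amide-type nitrogen gives a 1.3-fold lower number from compound 1 to compound 3 (0.11 log units; within the scatter), so this larger change also stays within the scatter. At this place, a ring carrying two chlorine atoms therefore cannot be told apart from one carrying a single fluorine. Nothing available gives a reason for this result.

The compounds shown leave open whether a ring bearing an amine, a carboxylic acid or a methoxy group would give a step beyond the scatter from compound 1.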